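Triazole series: a second chlorine on the N-aryl ring

A few compounds are considered here, and "the series" means these few. Any claim that something is new, unique, unknown or untested is made for them only; others in the source may bear on it.

In a functional assay on PC-12 cells (Rattus norvegicus) for cytotoxicity, read by MTT assay, with stated times of 2 h and 24 h, tested at 10 uM (on this read-out lower numbers stand for a weaker effect and higher numbers for a stronger effect at the one concentration tested), compound 1 `Oc1cc(C(F)(F)F)ccc1-c1nc(-c2ccccc2O)n(-c2ccc(OC(F)(F)F)cc2)n1` gives 92.5%, compound 2 `N#Cc1ccc(-n2nc(-c3ccc(C(F)(F)F)cc3O)nc2-c2ccccc2O)cc1` gives 98.9%, and compound 3 `Oc1cc(C(F)(F)F)ccc1-c1nc(-c2ccccc2O)n(-c2cccc(Cl)c2)n1` gives 100%. Compound 3 holds the highest of the three numbers, yet the gaps to compound 2 and to compound 1 both lie within the scatter, so no order among the three can be read from them. Compound 4 `Oc1cc(C(F)(F)F)ccc1-c1nc(-c2ccccc2O)n(-c2ccc(Cl)cc2Cl)n1` is not yet measured; it differs from compound 3 by 2,4-dichlorophenyl in place of 3-chlorophenyl on an aromatic nitrogen. For the measured compounds named here, two measured steps touch the same place on the shared core: a number 7.5 percentage points higher from compound 1 to compound 3 (within the scatter) and a number 1.1 percentage points higher from compound 2 to compound 3 (within the scatter); a third, a number 6.4 percentage points higher from compound 1 to compound 2 (within the scatter), changes a group on that same aryl ring. Each stays within the scatter, and all three read-outs sit near the top of the scale. On this basis no step beyond the scatter is expected in this assay for compound 4, and the step of a number 3 percentage points lower from compound 3 to compound 4 (within the scatter) is estimated as essentially flat. Compound 4 is expected to give about 97%, within a range from 85% to 103%.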

Compound 4, a percentage reported as activity, at one concentration (the size of the read-out at that concentration, not a potency): 95.2%
For compound 4 the middle estimate is 1.8 percentage points above the measured one, within the range that was stated.
By their numbers in this assay, from the lowest: compounds 1, 4, 2 and 3 (each within the scatter of the next).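

In this assay the 2,4-dichlorophenyl group on the aromatic nitrogen gives a number 4.8 percentage points lower from compound 3 to compound 4 (within the scatter) and a number 3.7 percentage points lower from compound 2 to compound 4 (within the scatter) and a number 2.7 percentage points higher from compound 1 to compound 4 (within the scatter) with no step beyond the scatter. The earlier compounds shown here carried one group on this aryl ring; compound 4 shows that a second chlorine also leaves the read-out within the scatter of the other three compounds, all near the top of the scale. No measurement on hand offers a cause for these small steps.

Still open, on these data alone, is whether a carboxylic acid or an amine on this aryl ring, or a longer alkyl chain in place of the ring on the aromatic nitrogen, would produce a step beyond the scatter. With all four compounds read at one concentration near the top of the scale, any difference in potency among them also remains unresolved.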